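The source may report more compounds than this note shows. Statements on the series, on what has been measured and on what is new or still open speak of the compounds shown alone.

Three compounds have numbers in an assay for inhibition of serine/threonine-protein kinase PLK2 (Homo sapiens), read by FRET and Z'-LYTE, with a stated time of 1 h; a higher number here means a weaker inhibitor, a lower number a stronger inhibitor. Compound 1 `CC[C@@H]1C(=O)N(C)c2cnc(Nc3ccc(S(N)(=O)=O)cc3)nc2N1C1CCCC1` gives 10.2 nM. Compound 3 `CC[C@@H]1C(=O)N(C)c2cnc(-n3ccc4cc(C(=O)NC5CCCC5)ccc43)nc2N1C1CCCC1` gives 7.06 nM. Compound 2 `CCC1C(=O)N(C)c2cnc(-n3ccc4cc(C(=O)NC(C)C)ccc43)nc2N1c1ccn(C)n1` gives 125 nM, the highest of the three numbers, which makes it the weakest inhibitor among them; its nearest neighbour is compound 1, and both the gap to compound 1 and the wider gap to compound 3 lie beyond the usual scatter of repeated measurements of this kind.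

Compound 4 `CCNC(=O)c1ccc2c(ccn2-c2ncc3c(n2)N(c2ccn(C)n2)C(CC)C(=O)N3C)c1` has not yet been measured in this assay. It differs from compound 2 in a single place: hydrogen in place of methyl on a saturated chain carbon bound to an amide-type nitrogen and a saturated chain carbon. Read one bond further out, the isopropylcarbamoyl group of compound 2 becomes an ethylcarbamoyl group in compound 4. Among the measured compounds shown here, no pair of measured compounds shows this change on its own, so the expectation rests only on the removal of one methyl group from an amide substituent. The step from compound 2 to compound 4 is expected to be a 1.0-fold higher number from compound 2 to compound 4 (0.02 log units; within the scatter), none beyond the scatter. Compound 4 is therefore estimated at 130 nM, with a range from 60 nM to 280 nM.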

Compound 4, half-maximal inhibitory concentration: 243 nM
Estimate against measurement, compound 4: 1.9-fold (0.27 log units) below; low and high end bracket the measured number.
By their numbers in this assay, from the lowest: compounds 3 and 1 (each within the scatter of the next); then compounds 2 and 4 (each within the scatter of the next).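

In this assay, among the compounds shown here, the change from isopropylcarbamoyl to ethylcarbamoyl gives a 1.9-fold higher number from compound 2 to compound 4 (0.29 log units; within the scatter) and is the first direct reading of this position, since no earlier pair isolated a single change here. On this background, then, taking one methyl off the saturated chain carbon bound to the amide-type nitrogen leaves the number within the scatter, so this pair shows no clear loss or gain in inhibition. Nothing on hand explains this result.

As far as these compounds go, how the number would respond to a larger change at this position remains open, for example with a plain methyl, a bare carboxamide carrying only hydrogens on its nitrogen, or a longer chain such as butyl. From the compounds shown here alone, this reading also rests on one pair, so whether the same change behaves alike on the other compounds remains unknown.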